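Replacing 3-hydroxypropyl on the aromatic oxygen of compound 1

A few compounds are considered here, and "the series" means these few. Any claim that something is new, unique, unknown or untested is made for them only; others in the source may bear on it.

In a functional assay on HL-60 cells (Homo sapiens) for cytotoxicity, read by MTT assay, with a stated time of 24 h (a lower number here means a stronger inhibitor, a higher number a weaker inhibitor), compound 1 `OCCCOc1c(Br)cc(Br)cc1Oc1ccc(Br)cc1Br` gives 29.9 ug/mL as its reading, compound 2 `COc1ccccc1N1CCN(CCCCCOc2c(Br)cc(Br)cc2Oc2ccc(Br)cc2Br)CC1` gives 32.2 ug/mL and compound 3 `CC(C)(C)OC(=O)N1CCN(CCCCCOc2c(Br)cc(Br)cc2Oc2ccc(Br)cc2Br)CC1` gives 32.1 ug/mL on the same read-out. All three numbers lie within the scatter of one another, so compound 1 holds no separate place among them. Compound 4 `CC(C)(C)C(=O)C(C#N)Oc1c(Br)cc(Br)cc1Oc1ccc(Br)cc1Br` has cyano((tert-butyl)carbonyl)methyl in place of 3-hydroxypropyl on an oxygen on an aromatic ring on the shared core. For the measured compounds named here, the only measured step bearing on this is a 1.0-fold lower number from compound 2 to compound 3 (0.00 log units; within the scatter) in this assay for tert-butoxycarbonyl in place of 2-methoxyphenyl on an amine nitrogen in a ring, and it stays within the scatter. The expectation rests on compound 1 at 29.9 ug/mL and on that step. Going by the values given here, no measured compound carries the entering group, so the range is kept wide. The estimated step is a 1.1-fold lower number from compound 1 to compound 4 (0.03 log units; within the scatter) and no move beyond the scatter is expected. Compound 4 is estimated at 28 ug/mL with an expected range from 13 ug/mL to 50 ug/mL in this assay.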

Compound 4, half-maximal inhibitory concentration: 29.2 ug/mL
Compound 4: middle estimate off by 1.0-fold (0.02 log units), on the low side; the measured number falls inside the stated range.
By their numbers in this assay, from the lowest: compounds 4, 1, 3 and 2 (each within the scatter of the next).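

In this assay, the step of a 1.0-fold lower number from compound 1 to compound 4 (0.01 log units; within the scatter) is the first one shown that alters the group directly on this oxygen on an aromatic ring, and it stays within the scatter. The exchange goes from 4 heavy atoms with 1 hydrogen-bond donor to 9 heavy atoms with 0 hydrogen-bond donors, and adds a carbonyl and a nitrile, yet it gives no separation in this read-out, whereas the earlier step concerned only the substituent on an amine nitrogen in a ring. Nothing available explains this flat result.

As far as these compounds go, whether any group on this oxygen can move the reading beyond the scatter remains open, since all four compounds lie close together. A carboxylic acid, a primary amine or a plain methyl group at this place would test that.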